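The compounds below may be only part of what the source reports. "The series", "measured", "known", "first", "only" and "open" are said of these compounds alone.

Measured compounds:
- Compound 1, `COc1cc(-c2nnc(SCC(=O)c3ccc(F)c(F)c3)n2N)cc(OC)c1OC`: in a functional assay on PC-3 cells (Homo sapiens) for antiproliferative activity, read by MTT assay, with a stated time of 48 h (a higher number here means a weaker inhibitor, a lower number a stronger inhibitor), compound 1 gives > 100000 nM, which is a limit of the assay.
- Compound 2, `COc1cc(-c2nnc(SCC(=O)c3ccccc3F)n2N)cc(OC)c1OC`: in this assay compound 2 gives 43100 nM.
- Compound 3, `COc1cc(-c2nnc(SCC(=O)Nc3ccc(C)cc3)n2N)cc(OC)c1OC`: in this assay compound 3 gives 43100 nM.

Compound 3 stands level with compound 2 at the digits shown, the step of no change at the digits printed from compound 2 to compound 3 (within the scatter) lying within the scatter. Among the compounds with values here, the only other value, that of compound 1, is a limit (the limit of > 100000 nM in this assay, at which 1 of the 3 values shown sits), so the two steps away from it, an at least 2.3-fold lower number from compound 1 to compound 2 (0.36 log units; beyond the scatter) and an at least 2.3-fold lower number from compound 1 to compound 3 (0.36 log units; beyond the scatter), are read only as at least modest lowerings.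

Compound 4, `COc1cc(-c2nnc(SCC(=O)Nc3ccccc3F)n2N)cc(OC)c1OC`, differs from compound 3 in one place: 2-fluorophenyl in place of 4-methylphenyl on an amide-type nitrogen. Within the data shown here, no measured step exchanges one aryl group for another on an amide-type nitrogen. The nearest point of comparison is that the 2-fluorophenyl ketone of compound 2 and the 4-methylphenyl amide of compound 3 sit at the same number in this assay, and that the move to 2-fluorophenyl from 3,4-difluorophenyl on the carbonyl carbon, an at least 2.3-fold lower number from compound 1 to compound 2 (0.36 log units; beyond the scatter), lowered the number. On this footing the step of a 1.1-fold lower number from compound 3 to compound 4 (0.03 log units; within the scatter) is expected to stay within the scatter. Compound 4 is therefore estimated at 40000 nM in this assay, with a range from 15000 nM to 110000 nM.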

Compound 4, half-maximal inhibitory concentration: 36700 nM
Estimate against measurement, compound 4: 1.1-fold (0.04 log units) above; the measured number falls inside the stated range.
By their numbers in this assay, from the lowest: compounds 4, 2 and 3 (each within the scatter of the next). At a limit, above all of these: compound 1.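

On the amide-type nitrogen, the exchange of one aryl group for another reads a 1.2-fold lower number from compound 3 to compound 4 (0.07 log units; within the scatter), so 2-fluorophenyl and 4-methylphenyl are not told apart at this place in this assay. With the 2-fluorophenyl group kept, the change from the ketone to the amide reads a 1.2-fold lower number from compound 2 to compound 4 (0.07 log units; within the scatter), so these two linkages are not told apart either. The step of an at least 2.7-fold lower number from compound 1 to compound 4 (0.43 log units; beyond the scatter) is read only as at least modest, compound 1 being a limit of the assay: the limit of > 100000 nM in this assay, at which 1 of the 4 values shown sits.

From the compounds shown here alone, it remains open whether 3,4-difluorophenyl on the amide-type nitrogen would also reach this limit, as it does on the carbonyl carbon in compound 1. Also open, going by these compounds, is whether a dimethylamino group or a carboxylic acid on the aryl ring of the amide would move the number beyond the scatter.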